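Swapping chloro for hydrogen: permeability of a bispyridinium oxime

The compounds below may be only part of what the source reports. "The series", "measured", "known", "first", "only" and "open" are said of these compounds alone.

Measured compounds:
compound 1 `NC(=O)c1cc[n+](C/C=C/C[n+]2cc(Cl)c(/C=N/O)c(Cl)c2)cc1`, 2.21 10^-6 cm/s
compound 2 `NC(=O)c1cc[n+](CCC[n+]2ccc(/C=N/O)c(Cl)c2)cc1`, 1.4 10^-6 cm/s
compound 3 `NC(=O)c1cc[n+](CCC[n+]2ccc(/C=N/O)cc2)cc1`, 0.33 10^-6 cm/s

In an ADME assay for permeability, using PAMPA, with a stated time of 6 h, tested at 100 uM (on this read-out lower numbers stand for lower permeability and higher numbers for higher permeability), compound 1 gives 2.21 10^-6 cm/s, and compound 2 gives 1.4 10^-6 cm/s, two values within the scatter of each other. The difference between the cores of compound 1 and compound 2 is not broken down here. Compound 3 gives 0.33 10^-6 cm/s; the change hydrogen in place of chloro on an aromatic carbon made a 4.2-fold lower number from compound 2 to compound 3 (0.63 log units; beyond the scatter). Compound 4 `NC(=O)c1cc[n+](C/C=C/C[n+]2ccc(/C=N/O)c(Cl)c2)cc1` is not yet measured. It differs from compound 1 by hydrogen in place of chloro on an aromatic carbon, the same kind of change, though here the place is also meta to a chloro group. Because compound 1 starts at 2.21 10^-6 cm/s and the earlier step was a 4.2-fold lower number from compound 2 to compound 3 (0.63 log units; beyond the scatter), a somewhat smaller drop is expected: compound 4 is estimated at 0.9 10^-6 cm/s, a step of a 2.5-fold lower number from compound 1 to compound 4 (0.39 log units; beyond the scatter) in this assay.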

Compound 4, apparent permeability: 2.6 10^-6 cm/s
Compound 4: middle estimate off by 2.9-fold (0.46 log units), on the low side; the measured number lies above the stated range.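

In this assay, putting hydrogen in place of chloro on an aromatic carbon gave a 1.2-fold higher number from compound 1 to compound 4 (0.07 log units; within the scatter) and so did not repeat the earlier drop. The size of this step therefore did not carry from one core to the other: the same change on two cores in this assay, a 4.2-fold lower number (0.63 log units; beyond the scatter) from compound 2 to compound 3 and a 1.2-fold higher number (0.07 log units; within the scatter) from compound 1 to compound 4, 5.0-fold (0.70 log units) apart, beyond the scatter of two such steps. For the compounds shown here, with only two pairs, this shows that the step cannot be assumed to transfer, but not which of the differences between the cores is responsible or how the change would behave on a further core.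

The compounds shown leave open how a fluoro or methyl group in the same place would compare with chloro and hydrogen on each core. They also leave open whether an amine there would follow either step.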